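The source may report more compounds than this note shows. Statements on the series, on what has been measured and on what is new or still open speak of the compounds shown alone.

Measured so far in a functional assay on ACHN cells (Homo sapiens) for cytotoxicity, read by sulforhodamine B assay, with a stated time of 72 h; on this read-out higher numbers stand for weaker inhibition of growth and lower numbers for stronger inhibition of growth:
Compound 1 `O=C(Nc1ccc(C(F)(F)F)cc1)C1CCc2ccccc2N1`: 25000 nM
Compound 2 `O=C(Nc1ccc(O)cc1)C1CCc2ccccc2N1`: > 100000 nM

Compound 2 is reported only as a limit, > 100000 nM, and not as a number. That places it at the limit of > 100000 nM in this assay, at which 1 of the 2 values shown sits.

Compound 3 `COc1ccc(NC(=O)C2CCc3ccccc3N2)cc1` differs from compound 2 in one place, methyl in place of hydrogen on an oxygen on an aromatic ring, so hydroxy becomes methoxy. For the measured compounds named here, one measured step bears on this, an at least 4.0-fold higher number from compound 1 to compound 2 (0.60 log units; beyond the scatter), where hydroxy took the place of trifluoromethyl on an aromatic carbon. Going by the values given here, no measured step shows what methyl does on that oxygen, so this is a weak guide.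

A modest move to lower numbers in this assay is expected, with a fair chance that compound 3 again gives only a limit. The expected change is an at least 1.4-fold lower number from compound 2 to compound 3 (0.15 log units; that floor lies within the scatter). For compound 3 the estimate is 70000 nM, with an expected range of 25000 nM to 150000 nM.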

Compound 3, concentration for 50% growth inhibition: 38000 nM
Beside the measured number, compound 3's estimate is 1.8-fold (0.27 log units) above it, within the range that was stated.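

In this assay, putting methyl on the oxygen of the hydroxy group turns an unquantified result into a measured one, with an at least 2.6-fold lower number from compound 2 to compound 3 (0.42 log units; beyond the scatter). Compound 2 stands only as a limit, > 100000 nM. Methoxy and trifluoromethyl cannot be told apart at this place, with a 1.5-fold higher number from compound 1 to compound 3 (0.18 log units; within the scatter), so among these three groups only hydroxy stands apart in this assay.

On these data alone, it remains open whether other groups at this place, such as an amine, a carboxylic acid or a longer chain on the oxygen, would bring the number clearly lower than the values seen so far. As far as these compounds go, the shared core is the same in all three compounds, so what changes elsewhere in the molecule would do also stays unknown.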